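Ethoxy homologue of compound 2: expected cytotoxicity

The compounds below may be only part of what the source reports. "The series", "measured", "known", "first", "only" and "open" are said of these compounds alone.

Compound 2 `COc1ccc2c(c1)OC(c1ccc(Cl)cc1)C(c1ccccc1)C2=O` is the methoxy member of the series bearing a 4-chlorophenyl group on a saturated ring carbon. In an ADME assay on PBMC cells (Homo sapiens) for cytotoxicity, read by MTT assay, with a stated time of 5 days (on this read-out lower numbers stand for higher toxicity in this test and higher numbers for lower toxicity in this test), compound 2 gives only a limit of the assay, > 2500000 nM. Compound 1 `COc1ccc2c(c1)OC(c1cccc([N+](=O)[O-])c1)C(c1ccccc1)C2=O` likewise gives only a limit in this assay, > 2500000 nM. Compound 3 `CCOc1ccc2c(c1)OC(c1ccc([N+](=O)[O-])cc1)C(c1ccccc1)C2=O`, an ethoxy analogue with a 4-nitrophenyl group, gives a number in this assay, 1360000 nM.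

Going by the values given here, the one single-point step among the measured compounds, a step that the two limits leave unreadable from compound 1 to compound 2, cannot be sized because the limit of > 2500000 nM in this assay, at which 2 of the 3 values shown sit, closes off both of its ends. Compound 4 `CCOc1ccc2c(c1)OC(c1ccc(Cl)cc1)C(c1ccccc1)C2=O` differs from compound 2 by methyl in place of hydrogen on a saturated chain carbon bound to an oxygen on an aromatic ring. Among the compounds with values here, no measured step isolates this change. Compound 1 and compound 3 differ at the alkoxy group and at the aryl group at the same time, and their two values show a limit for compound 1 and a plain number for compound 3, which settles nothing about the alkoxy change alone.

Nothing measured therefore points to a step in this assay beyond the scatter, and a reading at or near the limit is expected. For compound 4 the expected value in this assay is 2500000 nM, ranging from 1000000 nM to 6000000 nM. The expected step is a number no higher from compound 2 to compound 4 (the limit leaves the size open).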

Compound 4, half-maximal cytotoxic concentration: > 2500000 nM
Compound 4 gave a limit, no number; the forecaster's own chance of this, stated with the estimate: 60%; the middle value sits exactly at the limit.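

Compound 4 gives only a limit in this assay, as compound 2 does, so the methoxy to ethoxy change cannot be sized, and no step that has a limit at both ends can be read; the series now rests mostly on one ceiling: the limit of > 2500000 nM in this assay, at which 3 of the 4 values shown sit.

Going by these compounds alone, the one readable step, for chloro in place of nitro on an aromatic carbon, is an at least 1.8-fold higher number from compound 3 to compound 4 (0.26 log units; that floor lies within the scatter), and this gives the first link between the numeric result of compound 3 and a compound that stops at the limit, though only as a floor. Compound 4 also shows that an ethoxy group does not by itself bring a number in this assay, since it carries that group and still stops at the limit, so the number for compound 3 cannot be credited to the ethoxy group alone.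

On these data alone, whether methyl in place of hydrogen at this place moves the read-out at all stays open, and so does any real size for the chloro to nitro change. A longer chain such as propoxy in place of ethoxy, or an amine on the aryl group, also remains unplaced in this assay among the compounds shown.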